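A few compounds are considered here, and "the series" means these few. Any claim that something is new, unique, unknown or untested is made for them only; others in the source may bear on it.

For the measured compounds named here, compound 2 `O=C(/C=C/c1ccccc1[N+](=O)[O-])NNC(=O)c1ccc2c(c1)OCCO2` stands lowest of the two numbers measured so far: in a functional assay on cells (Cancer cell lines, Homo sapiens) for inhibition, read by MTT assay, with a stated time of 48 h (a lower number here means a stronger inhibitor, a higher number a weaker inhibitor), compound 2 gives 890 nM, while compound 1 `O=C(/C=C/c1ccc(Br)cc1)NNC(=O)c1ccc2c(c1)OCCO2` gives 2330 nM. Compound 3 `O=C(/C=C/c1ccccc1Cl)NNC(=O)c1ccc2c(c1)OCCO2` differs from compound 2 by chloro in place of nitro on an aromatic carbon. Going by the values given here, the only measured step, a 2.6-fold lower number from compound 1 to compound 2 (0.42 log units; beyond the scatter), put 2-nitrophenyl in place of 4-bromophenyl and so bears on this change only loosely, since a halogen there went with the higher number. A modest rise in this assay therefore seems likely. Compound 3 is expected at 1500 nM, within 700 nM to 3500 nM. That expectation means a step of a 1.7-fold higher number from compound 2 to compound 3 (0.23 log units; within the scatter).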

Compound 3, half-maximal inhibitory concentration: 4880 nM
Beside the measured number, compound 3's estimate is 3.3-fold (0.51 log units) below it; the measured number lies above the stated range.
By their numbers in this assay, from the lowest: compound 2; then compound 1; then compound 3.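

In this assay, chloro in place of nitro on an aromatic carbon, ortho to a large group, gives a 5.5-fold higher number from compound 2 to compound 3 (0.74 log units; beyond the scatter) and so shows that the number depends on the group held at this place. The change from 4-bromophenyl to 2-chlorophenyl gives a 2.1-fold higher number from compound 1 to compound 3 (0.32 log units; beyond the scatter) and so shows that the two halogen-bearing compounds do not share one number. Nothing at hand explains either step. On these data alone, whether an amine or a carboxylic acid on this aromatic carbon would give a number nearer that of compound 2 or compound 3 stays open.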